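Methyl Added to the Chloronaphthyl Ether of Compound 3

The compounds below may be only part of what the source reports. "The series", "measured", "known", "first", "only" and "open" are said of these compounds alone.

Compound 1 `Cc1cc(S(N)(=O)=O)ccc1NC(=O)COc1ccc(F)cc1Oc1cccc2ccccc12` gives 33100 nM in an ADME assay on C8166 cells (Homo sapiens) for cytotoxicity, read by MTT assay; on this read-out lower numbers stand for higher toxicity in this test and higher numbers for lower toxicity in this test. Compound 2 `Cc1cc(S(N)(=O)=O)ccc1NC(=O)COc1ccc(F)cc1Oc1ccc2ccccc2c1` gives 68600 nM. Compound 3 `Cc1cc(S(N)(=O)=O)ccc1NC(=O)COc1ccc(F)cc1Oc1ccc2ccccc2c1Cl` gives 47100 nM.

Among these three numbers compound 3 is separated from its neighbours only by steps inside the usual scatter: a 1.4-fold higher number from compound 1 to compound 3 (0.15 log units; within the scatter) and a 1.5-fold lower number from compound 2 to compound 3 (0.16 log units; within the scatter). Among the measured compounds shown here, the one step that reaches beyond the scatter is a 2.1-fold higher number from compound 1 to compound 2 (0.32 log units; beyond the scatter), a modest one.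

Compound 4 `Cc1cc(S(N)(=O)=O)ccc1NC(=O)COc1ccc(F)cc1Oc1c(C)cc2ccccc2c1Cl` differs from compound 3 in one place: methyl in place of hydrogen on an aromatic carbon. For the measured compounds named here, no measured step adds a methyl anywhere. The step that bears most on it is the addition of a single small group to the same ring, a 1.5-fold lower number from compound 2 to compound 3 (0.16 log units; within the scatter), which stayed within the scatter, and even the exchange of the whole naphthyl arrangement, a 2.1-fold higher number from compound 1 to compound 2 (0.32 log units; beyond the scatter), moved the number only modestly. Compound 4 is therefore expected to show a 1.1-fold lower number from compound 3 to compound 4 (0.05 log units; within the scatter), that is, no step beyond the scatter. Compound 4 is estimated at 42000 nM, with a range from 20000 nM to 85000 nM.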

Compound 4, half-maximal cytotoxic concentration: 55600 nM
Beside the measured number, compound 4's estimate is 1.3-fold (0.12 log units) below it; the measured number falls inside the stated range.
By their numbers in this assay, from the lowest: compounds 1, 3, 4 and 2 (each within the scatter of the next, the first and the last beyond it).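

Methyl on this aromatic carbon, ortho to a large group and meta to the chloro group, gives the first methyl step in this assay, and that step stays within the scatter (a 1.2-fold higher number from compound 3 to compound 4 (0.07 log units; within the scatter)). The 1-chloro-3-methylnaphthalen-2-yl group also stays within the scatter of both plain naphthyl ethers (a 1.2-fold lower number from compound 2 to compound 4 (0.09 log units; within the scatter)) and (a 1.7-fold higher number from compound 1 to compound 4 (0.23 log units; within the scatter)), so the methyl separates compound 4 from none of the three earlier compounds. Nothing available explains these small steps or ties them to any property of the methyl group.

On these data alone, whether an amine, a carboxylic acid or a longer chain such as propyl on this carbon would give a step beyond the scatter remains open. Also open, as far as these compounds go, is how methyl on this carbon reads without the chloro group.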